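The source may report more compounds than this note shows. Statements on the series, on what has been measured and on what is new or still open speak of the compounds shown alone.

Among the compounds with values here, in a functional assay on UACC-62 cells (Homo sapiens) for inhibition, read by sulforhodamine B assay, with a stated time of 48 h (a lower number here means a stronger inhibitor of growth, a higher number a weaker inhibitor of growth), compound 2 (`COc1cc(-c2nn(-c3cccc(NC(=O)Nc4ccc(Cl)c(Cl)c4)c3)cc2-c2ccncc2)ccc1Cl`) gives 773 nM and stands at the low end of the three numbers so far. Compound 3 (`O=C(Nc1cccc(-n2cc(-c3ccncc3)c(-c3ccc(Cl)c(O)c3)n2)c1)Nc1ccc(Cl)c(Cl)c1`) gives 1110 nM, within the scatter of compound 2, while compound 1 (`COc1cc(-c2nn(-c3cccc(NC(=O)c4cccc(C(F)(F)F)c4)c3)cc2-c2ccncc2)ccc1Cl`) gives 1940 nM, a higher number beyond the scatter.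

The change to compound 4 (`COc1cc(-c2nn(-c3cccc(NC(=O)c4ccccc4)c3)cc2-c2ccncc2)ccc1Cl`) is phenyl in place of (3,4-dichlorophenyl)amino on a carbonyl carbon, which puts phenyl in place of (3,4-dichlorophenyl)amino on a carbonyl carbon. The measured step closest to this is a 2.5-fold lower number from compound 1 to compound 2 (0.40 log units; beyond the scatter), a modest one that put (3,4-dichlorophenyl)amino in place of 3-(trifluoromethyl)phenyl on a carbonyl carbon. Within the data shown here, the new change runs the opposite way, but it ends at phenyl rather than 3-(trifluoromethyl)phenyl, and no measured compound carries phenyl there. The other measured step, a 1.4-fold higher number from compound 2 to compound 3 (0.16 log units; within the scatter), concerns hydrogen in place of methyl on an oxygen and does not bear on this change.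

A step of similar or somewhat larger size towards a higher number is therefore expected in this assay. The expected step is a 3.2-fold higher number from compound 2 to compound 4 (0.51 log units; beyond the scatter). Compound 4 is estimated at 2500 nM, with an expected range of 1000 nM to 6500 nM.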

Compound 4, concentration for 50% growth inhibition: 692 nM
Beside the measured number, compound 4's estimate is 3.6-fold (0.56 log units) above it; the measured number lies below the stated range.
By their numbers in this assay, from the lowest: compounds 4, 2, 3 and 1 (each within the scatter of the next, the first and the last beyond it).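

In this assay, phenyl in place of (3,4-dichlorophenyl)amino on a carbonyl carbon gives a 1.1-fold lower number from compound 2 to compound 4 (0.05 log units; within the scatter), so the two groups cannot be told apart here. Hydrogen in place of trifluoromethyl on an aromatic carbon gives a 2.8-fold lower number from compound 1 to compound 4 (0.45 log units; beyond the scatter), which shows that plain phenyl on the carbonyl carbon matches what the earlier step had reached only with (3,4-dichlorophenyl)amino, and that compound 1, with its trifluoromethyl, stands apart from both compound 2 and compound 4. Nothing available explains why these numbers fall as they do.

The compounds shown leave open whether a smaller group such as fluorine or methyl on that aromatic carbon would behave like hydrogen or like trifluoromethyl. They also leave open whether plain phenylamino on the carbonyl carbon would match phenyl.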